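This account rests on a few compounds, and the source may have more. Where it says the series, first, only, none or still open, it means among the compounds named here.

Compound 1 (`C=CCCCCCOc1ncc(-c2ccccc2OCCCCC=C)n1C`) gives 62000 nM
Compound 2 (`CCCCCCOc1ncc(-c2ccccc2OC)n1C`) gives 37000 nM

Both values come from a functional assay on A549 cells (Homo sapiens) for inhibition, read by colorimetric assay and MTT assay, with a stated time of 72 h; on this read-out lower numbers stand for stronger inhibition and higher numbers for weaker inhibition. On these two numbers, compound 2 cannot be separated from compound 1, since the gap between them lies within the scatter of repeated measurements.

The next compound to be read is compound 3 (`COc1ccccc1-c1cnc(OC)n1C`). It differs from compound 2 by hydrogen in place of pentyl on a saturated chain carbon bound to an oxygen on an aromatic ring, with hydrogen in place of pentyl on a saturated chain carbon bound to an oxygen on an aromatic ring. Cut one bond further out, this is hexyl to methyl, or hexyloxy to methoxy.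

Among the compounds with values here, the series holds no measured step that isolates a single change, so any expectation here is tentative. Compound 2 (37000 nM) offers the only direct reference point. A modest move toward a higher number, meaning weaker inhibition, is expected, and it may not go far beyond the scatter. The estimated change (a 1.9-fold higher number from compound 2 to compound 3 (0.28 log units; within the scatter)) is therefore small. For compound 3, the expected value in this assay is 70000 nM, with an estimated range from 25000 nM to 200000 nM.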

Compound 3, half-maximal inhibitory concentration: > 100000 nM
Compound 3 gave a limit, no number; the forecaster's own chance of this, stated with the estimate: 30%; middle value at least 1.4-fold (0.15 log units) away from the limit.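

Within the data shown here, replacing hexyloxy with methoxy at this place gives an at least 2.7-fold higher number from compound 2 to compound 3 (0.43 log units; beyond the scatter) in this assay, the first single change to be read and one that lies beyond the scatter. So the pentyl portion of the hexyl chain, on a saturated chain carbon bound to an oxygen on an aromatic ring, matters for inhibition on this read-out, and shortening the chain to methyl weakens it. Compound 3 yields only a limit, not a number, so the step gives a minimum size and its full extent stays unknown because the reading ends there: the limit of > 100000 nM in this assay, at which 1 of the 3 values shown sits.

The compounds shown leave open how inhibition changes with chain length at this place, since a butyl chain, a longer chain such as octyl, or a terminal amine on the hexyl chain could each show whether the trend continues or whether the chain can carry other groups. They also leave open whether the step holds beyond this one cell line, and whether any change at this place can move compound 2, at 37000 nM, to a much lower number.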